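The source may hold more compounds than are shown below. What is called first, only, known or untested is meant among the compounds shown, and "the series" means these compounds.

Compound 1 `CCc1ccc(OC)cc1CCc1ccc(O)c(C(=O)OC)c1`: 130 nM
Compound 2 `CCc1ccc(OC)c(CCc2ccc(O)c(C(=O)OC)c2)c1`: 430 nM

In a functional assay on HaCaT cells (Homo sapiens) for antiproliferative activity, read by sulforhodamine B assay, with a stated time of 3 days (a higher number here means a weaker inhibitor, a lower number a stronger inhibitor), compound 2 gives 430 nM, the higher of the two numbers, which makes it the weaker inhibitor of the pair. Its gap to compound 1 at 130 nM lies beyond the scatter.

Compound 3 `CCc1ccc(CC)c(CCc2ccc(O)c(C(=O)OC)c2)c1` has not yet been measured in this assay. It differs from compound 2 in one place: ethyl in place of methoxy on an aromatic carbon. The rest of the structure is unchanged.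

Going by the values given here, no measured pair shows this exchange, so the data give no direct guide to its size, and the expectation is correspondingly loose. A small move toward weaker inhibition is expected, possibly no larger than the scatter. The estimated change is a 1.2-fold higher number from compound 2 to compound 3 (0.07 log units; within the scatter).

For compound 3 the expected value is 500 nM, with an estimated range of 170 nM to 1500 nM.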

Compound 3, half-maximal inhibitory concentration: 650 nM
Compound 3: middle estimate off by 1.3-fold (0.11 log units), on the low side; measured number inside the range.
By their numbers in this assay, from the lowest: compound 1; then compounds 2 and 3 (each within the scatter of the next).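

In this assay, ethyl in place of methoxy, on the carbon ortho to a large group and para to an ethyl group, gives a 1.5-fold higher number from compound 2 to compound 3 (0.18 log units; within the scatter), so at this position the exchange of a group with one hydrogen-bond acceptor for one with none does not move the number beyond the scatter. The same exchange read from the other methoxy placement, on the same ring of compound 1, gives a 5.0-fold higher number from compound 1 to compound 3 (0.70 log units; beyond the scatter), which is beyond the scatter, so the size of this exchange depends on where the methoxy stood and the two steps cannot be treated as a single effect of ethyl. No measurement in hand explains why the two placements differ in this way.

The compounds shown leave open whether the tolerance at this position extends beyond ethyl, for example to a longer chain such as butyl, or to an amine or a carboxylic acid. They also leave open whether any group at this position would bring the number back toward that of compound 1, since only methoxy and ethyl have been compared here.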